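From trifluoromethyl to butylamino: compound 1 and compound 4

The source may hold more compounds than are shown below. What is called first, only, known or untested is meant among the compounds shown, and "the series" means these compounds.

Measured so far in a functional assay on HEK293 cells (Homo sapiens) for cytotoxicity (on this read-out higher numbers stand for lower toxicity in this test and lower numbers for higher toxicity in this test), for three compounds:
compound 1 `COc1ccc([C@H]2CC(=O)N(c3cccc(C(F)(F)F)c3)C2)cc1OC1CCCC1` gives > 10000 nM as a limit
compound 2 `COc1ccc([C@H]2CC(=O)N(c3ccccn3)C2)cc1OC1CCCC1` gives > 10000 nM as a limit
compound 3 `COc1ccc([C@H]2CC(=O)N(c3ccc(S(C)(=O)=O)cc3)C2)cc1OC1CCCC1` gives > 10000 nM as a limit

Each of these three values is a limit and not a number. Compound 1 stands at the limit of > 10000 nM in this assay, at which 3 of the 3 values shown sit, and so has no exact value of its own. Compound 4 `CCCCNc1cccc(N2C[C@@H](c3ccc(OC)c(OC4CCCC4)c3)CC2=O)c1` differs from compound 1 by butylamino in place of trifluoromethyl on an aromatic carbon and thus carries butylamino in place of trifluoromethyl on an aromatic carbon.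

Three measured steps exchange the whole group on an amide-type nitrogen in a ring, and they bear on this change only loosely. They are a step that the two limits leave unreadable from compound 1 to compound 2 then a step that the two limits leave unreadable from compound 1 to compound 3 and finally a step that the two limits leave unreadable from compound 2 to compound 3 and none of them has a readable size. Going by the values given here, no measured compound carries butylamino, so the direction remains open.

Compound 1 gives > 10000 nM as a limit and remains the only anchor for the expectation. No step beyond the usual scatter is expected, and the estimated change is a step that the limit leaves unreadable from compound 1 to compound 4 with no firm direction. Compound 4 is estimated at 12000 nM with an expected range from 5000 nM to 30000 nM and may well come out only as a limit.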

Compound 4, half-maximal cytotoxic concentration: > 10000 nM
Compound 4 was reported as a limit (the forecaster's own chance of this, stated with the estimate: 75%); the middle value lies beyond the limit too.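

In this assay no step can be read from compound 1 to compound 4, because the values of both compounds are limits and not numbers: the limit of > 10000 nM in this assay, at which 4 of the 4 values shown sit.

The compounds shown leave open whether butylamino in place of trifluoromethyl changes the cytotoxicity at all, and at what concentration any of these compounds would reach the half-maximal cytotoxic effect.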